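Swapping Phenyl for Bromofluorophenyl on a Weakly Cytotoxic Scaffold

The compounds below may be only part of what the source reports. "The series", "measured", "known", "first", "only" and "open" are said of these compounds alone.

Compound 3 `Cn1ccc2c(Oc3ccc(NC(=O)c4nn(-c5ccccc5)ccc4=O)cc3)ccnc21` was tested in a functional assay on HepG2 cells (Homo sapiens) for cytotoxicity, read by MTT assay, with a stated time of 72 h (a lower number here means a stronger inhibitor, a higher number a weaker inhibitor), where compound 3 gives 56200 nM. Compound 1 `O=C(Nc1ccc(Oc2ccnc3[nH]ccc23)cc1)c1nn(-c2ccc(Br)cc2F)ccc1=O`, which carries the 4-bromo-2-fluorophenyl group described below but lacks the methyl on the shared core, gives 46400 nM in this assay. Compound 2 `Cn1ccc2c(Oc3ccc(NC(=O)c4nn(-c5ccc(Cl)cc5)ccc4=O)cc3)ccnc21` gives only a limit in this assay, namely > 60000 nM. Of the two numbers that are not limits, compound 3 and compound 1 lie within the scatter of each other, so neither can be called the weaker one. Among the measured compounds shown here, the single measured step between neighbours, an at least 1.0-fold lower number from compound 2 to compound 3 (0.02 log units; that floor lies within the scatter), also stays within the scatter, and the limit of > 60000 nM in this assay, at which 1 of the 3 values shown sits, shows how close these compounds sit to the edge of what the assay can report.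

Compound 4 `Cn1ccc2c(Oc3ccc(NC(=O)c4nn(-c5ccc(Br)cc5F)ccc4=O)cc3)ccnc21` differs from compound 3 in one place: 4-bromo-2-fluorophenyl in place of phenyl on an aromatic nitrogen. For the measured compounds named here, no measured step tests exactly this change, but compound 1 carries the same group and gives 46400 nM, close to compound 3. The change from compound 3 to compound 4 is therefore expected to stay within the scatter, a 1.1-fold lower number from compound 3 to compound 4 (0.05 log units; within the scatter). Compound 4 is estimated at 50000 nM, with a range from 25000 nM to 100000 nM, and a real chance that only a limit is reported.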

Compound 4, half-maximal inhibitory concentration: 31200 nM
The estimate for compound 4 lay 1.6-fold (0.20 log units) above the measured number, within the range that was stated.
By their numbers in this assay, from the lowest: compounds 4, 1 and 3 (each within the scatter of the next). At a limit, above all of these: compound 2.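

Putting 4-bromo-2-fluorophenyl in place of phenyl on the aromatic nitrogen, with the rest of the molecule held fixed, gives a 1.8-fold lower number from compound 3 to compound 4 (0.26 log units; within the scatter), so this position now has a direct test of the change, and in this assay the two-halogen ring cannot be told apart from plain phenyl. With that same ring in place, methyl in place of hydrogen on the aromatic nitrogen of the shared core gives a 1.5-fold lower number from compound 1 to compound 4 (0.17 log units; within the scatter), so this second single change can also not be told apart from no change in this read-out. Against 4-chlorophenyl on the same position, the step is an at least 1.9-fold lower number from compound 2 to compound 4 (0.28 log units; that floor lies within the scatter), which is a floor and not a true size: the limit of > 60000 nM in this assay, at which 1 of the 4 values shown sits.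

Every group shown on this nitrogen is a phenyl ring, plain or with halogens, so it stays open how a non-aromatic group there, such as a short alkyl chain or a chain ending in an amine, would read in this assay. From the compounds shown here alone, how a phenyl ring carrying only bromine or only fluorine would compare with these compounds also stays open.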